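Adding bromo to the phenyl of compound 2

A few compounds are considered here, and "the series" means these few. Any claim that something is new, unique, unknown or untested is made for them only; others in the source may bear on it.

In an in vitro ADME assay on microsomes from liver (Homo sapiens) for metabolic stability, tested at 1 mg/mL (a lower number here means that the compound disappears faster, a higher number that the compound lasts longer), compound 1 `O=C(Nc1cc2cc[nH]c(=O)c2cc1Cl)C1CNCC1c1ccc(F)cc1` gives 1.02 h and compound 2 `O=C(Nc1cc2cc[nH]c(=O)c2cc1Cl)C1CNCC1c1ccccc1` gives 2.17 h. Among the measured compounds shown here, compound 2 therefore holds the higher of the two numbers so far, and the gap between them lies beyond the scatter.

The next structure is compound 3 `O=C(Nc1cc2cc[nH]c(=O)c2cc1Cl)C1CNCC1c1cccc(Br)c1`, which has bromo in place of hydrogen on an aromatic carbon. The change is phenyl to 3-bromophenyl, on a six-membered aromatic ring of carbon only, with the shared core untouched.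

For the measured compounds named here, only one measured step bears on this change: a 2.1-fold higher number from compound 1 to compound 2 (0.33 log units; beyond the scatter), a modest step with hydrogen in place of fluoro on an aromatic carbon. Read backwards, it pairs the halogen-bearing compound 1 with the lower number. Going by the values given here, that step concerns fluoro, and no measured compound carries bromo, so it offers only a rough guide to direction and size. A modest fall in this assay is the working expectation, and no change beyond the scatter remains possible.

The expected step is a 1.7-fold lower number from compound 2 to compound 3 (0.22 log units; within the scatter). Compound 3 is estimated at 1.3 h, with an expected range of 0.6 h to 2.6 h.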

Compound 3, half-life: 0.717 h
Estimate against measurement, compound 3: 1.8-fold (0.26 log units) above, within the range that was stated.
By their numbers in this assay, from the lowest: compounds 3 and 1 (each within the scatter of the next); then compound 2.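

In this assay, bromo on an aromatic carbon, meta to a large group, gives a 3.0-fold lower number from compound 2 to compound 3 (0.48 log units; beyond the scatter) and so places a second halogen-bearing compound on the lower side of the unsubstituted phenyl of compound 2; among these three compounds, none goes against this pattern. The exchange of 4-fluorophenyl for 3-bromophenyl, a 1.4-fold lower number from compound 1 to compound 3 (0.15 log units; within the scatter), leaves the two halogen-bearing compounds within the scatter of each other, so the higher number of compound 2 now stands apart from both of them, and the fall is no longer tied to fluoro alone. No measurement shown accounts for this fall in half-life.

Compound 1 and compound 3 differ in both the halogen and its place on the phenyl, so the contribution of each remains unresolved. From the compounds shown here alone, it also remains open whether a non-halogen group on the same aromatic carbon, such as methoxy or a carboxylic acid, would lower the number as bromo does or keep it near that of compound 2.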